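Urea to Amide Exchange in a Pyrazole Series

The source may report more compounds than this note shows. Statements on the series, on what has been measured and on what is new or still open speak of the compounds shown alone.

Measured so far:
compound 1, `O=C(Nc1cccc(-n2cc(-c3ccncc3)c(-c3cc(O)cc(Cl)c3)n2)c1)Nc1ccc(Cl)c(Cl)c1`, 102%
compound 2, `COc1cc(Cl)cc(-c2nn(-c3cccc(NC(=O)Nc4cc(C(F)(F)F)cc(C(F)(F)F)c4)c3)cc2-c2ccncc2)c1`, 97%
compound 3, `COc1cc(Cl)cc(-c2nn(-c3cccc(NC(=O)Nc4ccc(Cl)c(Cl)c4)c3)cc2-c2ccncc2)c1`, 96%

In a functional assay on KM12 cells (Homo sapiens) for inhibition, read by sulforhodamine B assay, with a stated time of 48 h, tested at 0.01 uM (on this read-out higher numbers stand for a weaker effect at the one concentration tested and lower numbers for a stronger effect), compound 1 gives 102%, compound 2 gives 97% and compound 3 gives 96%. All three values sit within the scatter of one another, so compound 3 is not separated from compound 1 or compound 2 on this read-out. Going by the values given here, the only single-point step recorded is a number 6 percentage points lower from compound 1 to compound 3 (within the scatter).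

Compound 4, `COc1cc(Cl)cc(-c2nn(-c3cccc(NC(=O)c4cccc(C(F)(F)F)c4)c3)cc2-c2ccncc2)c1`, differs from compound 3 in one place: 3-(trifluoromethyl)phenyl in place of (3,4-dichlorophenyl)amino on a carbonyl carbon. Among the compounds with values here, no measured step touches this change; the one available step was within the scatter, and every measured value sits near full activity. The step from compound 3 to compound 4 in this assay is therefore expected to be a number 2 percentage points higher from compound 3 to compound 4 (within the scatter). Compound 4 is estimated at 98%, between 88% and 108%.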

Compound 4, a percentage reported as activity, at one concentration (the size of the read-out at that concentration, not a potency): 110%
Compound 4: middle estimate off by 12 percentage points, on the low side, and the stated range ends below it.
By their numbers in this assay, from the lowest: compounds 3, 2, 1 and 4 (each within the scatter of the next, the first and the last beyond it).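

In this assay, the change from (3,4-dichlorophenyl)carbamoyl to (3-(trifluoromethyl)phenyl)carbonyl gives a number 14 percentage points higher from compound 3 to compound 4 (beyond the scatter), so this position shows a step beyond the scatter, which the change on the oxygen did not. The change removes the amino link and alters the ring substituents together, so the step cannot be assigned to either alone. Nothing measured here explains the step. The compounds shown leave open how a 3,4-dichlorophenyl ring joined directly to the carbonyl carbon would read. They also leave open how a 3-(trifluoromethyl)phenylamino group would read there.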